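A Further Methoxy Group on Compound 3

The source may report more compounds than this note shows. Statements on the series, on what has been measured and on what is new or still open speak of the compounds shown alone.

Of the compounds shown here, three built on a shared core have been tested in a functional assay on PC-3 cells (Homo sapiens) for inhibition, read by sulforhodamine B assay, with a stated time of 48 h; on this read-out higher numbers stand for lower toxicity in this test and lower numbers for higher toxicity in this test. Compound 1 `COc1cc(-c2cc(/C=C/C(=O)c3ccc(N)cc3)[nH]n2)cc(OC)c1OC` reaches only the limit of the test: in this assay compound 1 gives > 100000 nM, which is a limit and not a number. Compound 2 `COc1ccc(-c2cc(/C=C/C(=O)c3ccc(OC)c(OC)c3)[nH]n2)cc1` gives 8300 nM in this assay. Compound 3 `COc1ccc(-c2cc(/C=C/C(=O)c3cc(OC)c(OC)c(OC)c3)[nH]n2)cc1OC` gives 48200 nM in this assay, the highest of the two numbers shown; its nearest neighbour is compound 2, whose number is lower by a margin beyond the usual scatter.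

Compound 4 `COc1cc(C(=O)/C=C/c2cc(-c3cc(OC)c(OC)c(OC)c3)n[nH]2)cc(OC)c1OC` has not yet been measured. It differs from compound 3 in one place: methoxy in place of hydrogen on an aromatic carbon. Among the measured compounds shown here, no step between two measured compounds isolates this change, so the expectation rests on the spread of the numbers above. Compound 3 already sits at the high end of what has been measured, and compound 1 only reached the limit. Compound 4 is therefore expected to give a number near or above that of compound 3, with a real chance that only a limit is reported. The step of a 1.7-fold higher number from compound 3 to compound 4 (0.22 log units; within the scatter) is the estimated size of that move. In this assay compound 4 is expected to give about 80000 nM, within a range from 25000 nM to 250000 nM.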

Compound 4, concentration lethal to 50% of the cells: 7360 nM
For compound 4 the middle estimate is 11-fold (1.04 log units) above the measured one; measured number outside the range, below it.
By their numbers in this assay, from the lowest: compounds 4 and 2 (each within the scatter of the next); then compound 3. At a limit, above all of these: compound 1.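

In this assay, putting methoxy in place of hydrogen on an aromatic carbon, ortho to a methoxy group and meta to a large group, gives a 6.5-fold lower number from compound 3 to compound 4 (0.82 log units; beyond the scatter). This is the first step shown that isolates a single change, and it establishes that at this position the added methoxy group moves the number down, towards higher toxicity in this test, which the spread of the earlier compounds could not reveal. The step joins two real numbers, and compound 1 alone remains at a limit of the test and not at a number: the limit of > 100000 nM in this assay, at which 1 of the 4 values shown sits.

The compounds shown leave open whether a smaller or larger group at this position, such as a hydroxyl group, an ethoxy group or an amine, would lower the number as methoxy does or would leave it where compound 3 stands. Going by these compounds, this single step also rests on one position of one compound and carries no cause of its own, so whether methoxy has the same effect elsewhere on the shared core remains unknown.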